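Adding a second methyl to the benzamide ring of compound 1

This account rests on a few compounds, and the source may have more. Where it says the series, first, only, none or still open, it means among the compounds named here.

Measured compounds:
- compound 1, `Cc1ccc(C(=O)Nc2cc(-c3ccccc3)nn2-c2ccccc2)cc1`, 64 nM
- compound 2, `O=C(Nc1cc(-c2ccccc2)nn1-c1ccccc1)c1ccc(OC(F)(F)F)cc1`, 18 nM
- compound 3, `O=C(Nc1cc(-c2ccccc2)nn1-c1ccccc1)c1cc([N+](=O)[O-])cc([N+](=O)[O-])c1`, 65 nM

Three amides built on a shared core have been tested in a functional assay on cells for positive allosteric modulation of metabotropic glutamate receptor 5 (Rattus norvegicus), read by calcium flux; on this read-out higher numbers stand for an effect only at larger amounts of compound and lower numbers for an effect already at smaller amounts. Compound 1 carries a 4-methylphenyl on the amide and gives 64 nM, the second highest of the three numbers. Compound 3, with two nitro groups on that ring, gives 65 nM, a value within the scatter of compound 1, so the two cannot be ordered. Compound 2, with a trifluoromethoxy in place of the methyl, gives 18 nM; the step of a 3.6-fold lower number from compound 1 to compound 2 (0.55 log units; beyond the scatter) is modest but beyond the scatter.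

Compound 4, `Cc1ccc(C(=O)Nc2cc(-c3ccccc3)nn2-c2ccccc2)cc1C`, is not yet measured. It differs from compound 1 by methyl in place of hydrogen on an aromatic carbon, turning the 4-methylphenyl into a 3,4-dimethylphenyl. Among the measured compounds shown here, none of the measured steps concerns this change: the only step available, from compound 1 to compound 2, exchanges the group already present rather than adding a second one, and the pair of compound 1 and compound 3 shows no difference beyond the scatter. For the measured compounds named here, with no bearing step, a number close to compound 1 is expected, with the step of a 1.1-fold lower number from compound 1 to compound 4 (0.03 log units; within the scatter) expected to stay within the scatter. For compound 4 the estimate in this assay is 60 nM, with a range from 25 nM to 150 nM.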

Compound 4, half-maximal effective concentration: 20 nM
For compound 4 the middle estimate is 3.0-fold (0.48 log units) above the measured one; measured number below the stated range.
By their numbers in this assay, from the lowest: compounds 2 and 4 (each within the scatter of the next); then compounds 1 and 3 (each within the scatter of the next).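

In this assay, the added methyl gives a 3.2-fold lower number from compound 1 to compound 4 (0.51 log units; beyond the scatter), a step beyond the scatter and the first one here that concerns this aromatic carbon, ortho to a methyl group and meta to a large group. The earlier step from compound 1 exchanged the group already on the ring, whereas this one keeps that methyl and adds a second, showing that the number also responds to a substituent at a further ring position. A change of a single carbon atom is thus enough to produce a modest step, turning the 4-methylphenyl into a 3,4-dimethylphenyl. Nothing in the data at hand bears on the reason for this step.

The compounds shown leave open whether the methyl already present is needed for this step, and whether the same carbon would give a similar number when carrying a chlorine, a methoxy group or an amine instead. They also leave open whether a methyl on this carbon would move the number of compound 2 in the same direction and to a similar extent.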